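The compounds below may be only part of what the source reports. "The series", "measured", "known", "first", "only" and "open" are said of these compounds alone.

Compound 1 `C#CC(=O)N(Cc1ccc(OC)c(O)c1)c1cc(OC)c(OC)c(OC)c1` stands as the stronger of the two compounds measured in a functional assay on HCT-116 cells (Homo sapiens) for inhibition, read by MTT assay, with a stated time of 48 h (on this read-out lower numbers stand for stronger inhibition and higher numbers for weaker inhibition), where compound 1 gives 310 nM. The other measured compound, compound 2 `C/C=C/C(=O)N(Cc1cccc(O)c1)c1cc(OC)c(OC)c(OC)c1`, gives 6700 nM in this assay, a number that lies beyond the usual scatter from that of compound 1; since these two compounds differ in more than one place, the gap cannot be tied to a single change. Compound 3 `COc1ccc(CN(C(=O)CBr)c2cc(OC)c(OC)c(OC)c2)cc1O` has not yet been measured and differs from compound 1 in one place only: bromomethyl in place of ethynyl on a carbonyl carbon. The swap sits on a carbonyl carbon whose other neighbour is an amide-type nitrogen, so the core of compound 1 is kept intact. Among the compounds with values here, no measured pair shows what this swap does, so the expectation rests on compound 1 alone. Compound 1 gives 310 nM as the anchor. Compound 3 is therefore expected to land close by, a step of a 1.3-fold higher number from compound 1 to compound 3 (0.11 log units; within the scatter) that should stay within the usual scatter, with an estimated value of 400 nM and a range from 100 nM to 1600 nM.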

Compound 3, half-maximal inhibitory concentration: 68 nM
The estimate for compound 3 lay 5.9-fold (0.77 log units) above the measured number; the measured number lies below the stated range.
By their numbers in this assay, from the lowest: compound 3; then compound 1; then compound 2.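

In this assay, putting bromomethyl in place of ethynyl on a carbonyl carbon whose other neighbour is an amide-type nitrogen gives a 4.6-fold lower number from compound 1 to compound 3 (0.66 log units; beyond the scatter). This is the only pair shown that differs in one place, so this gap, unlike the one between compound 1 and compound 2, can be tied to a single change, and it shows that the triple bond of ethynyl is not needed at this position for a number in this range. Nothing measured here explains why the number falls with this swap.

The compounds shown leave open how a plain methyl or a chloromethyl group on this same carbonyl carbon would read, and so whether the bromine atom itself matters. A longer chain carrying bromine at its end also remains untested in what is shown here.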